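This account rests on a few compounds, and the source may have more. Where it says the series, first, only, none or still open, it means among the compounds named here.

Compound 1 `Nc1ccc(C(=O)NCCCOc2cccc(CN3CCCCC3)c2)cc1`: 6.82
Compound 2 `N#CN/C(=N\CCNC(=O)c1ccc(N=[N+]=[N-])cc1)NCCCOc1cccc(CN2CCCCC2)c1`: 7.9
Compound 3 `N#CN/C(=N\CCCNC(=O)c1ccccc1)NCCCCOc1cccc(CN2CCCCC2)c1`: 6.6

In a functional assay on cardiac atrium for antagonist activity at histamine H2 receptor (Cavia porcellus) (on this read-out lower numbers stand for lower potency and higher numbers for higher potency (the scale is a negative logarithm)), compound 2 gives the highest of the three numbers; compound 1 gives 6.82, lower by more than the usual scatter, and compound 3 gives 6.6, lower still and also beyond the scatter. Compound 4 `N#CN/C(=N\CCCCNC(=O)c1ccccc1)NCCCOc1cccc(CN2CCCCC2)c1` has not yet been measured. It differs from compound 2 in one place: 2-benzamidoethyl in place of ((4-azidophenyl)carbonyl)amino on a saturated chain carbon, two bonds along the chain from a double-bonded nitrogen. Among the compounds with values here, no measured pair shows this single change on its own, so its size can only be estimated. Compound 3, which also carries a plain benzamide, gives 6.6, and that points downward. Compound 4 is therefore expected to come in weaker than compound 2, an estimated step of a number 0.90 log units lower from compound 2 to compound 4 (beyond the scatter). The estimate for compound 4 is 7, with a range from 6.4 to 7.6.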

Compound 4, negative logarithm of the antagonist equilibrium constant: 6.81
Compound 4: the middle estimate sits 0.19 log units above what was measured; measured number inside the range.
By their numbers in this assay, from the lowest: compounds 3, 4 and 1 (each within the scatter of the next); then compound 2.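

In this assay, replacing ((4-azidophenyl)carbonyl)amino with 2-benzamidoethyl gives a number 1.09 log units lower from compound 2 to compound 4 (beyond the scatter), so this position on the chain is sensitive to the group it carries. The swap removes the azide and lengthens the chain by an ethyl unit in a single move, so the step belongs to the whole change, not to either part. Nothing available explains the drop. Which part carries the step remains open, as does whether a nitro or methoxy group in place of the azide would give a number like that of compound 2.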